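From 4-Methoxyphenyl to Cyclohexyl: an Expected Permeability Shift

A few compounds are considered here, and "the series" means these few. Any claim that something is new, unique, unknown or untested is made for them only; others in the source may bear on it.

Three compounds share one core and differ only in the group on an amide-type nitrogen in a ring. Compound 1 `CCCC[C@H](NC(=O)[C@H](CCCCN)NC(=O)[C@H](CCCNC(=N)N)NC(=O)c1ccc(/C=C2\SC(=S)N(CCCC)C2=O)cc1)C(N)=O` carries a butyl there; in an ADME assay for permeability, using PAMPA (a lower number here means that the compound crosses the layer more slowly, a higher number that the compound crosses the layer faster), compound 1 gives 1.61 10^-6 cm/s. Compound 2 `CCCC[C@H](NC(=O)[C@H](CCCCN)NC(=O)[C@H](CCCNC(=N)N)NC(=O)c1ccc(/C=C2\SC(=S)N(Cc3ccc(OC)cc3)C2=O)cc1)C(N)=O` carries a 4-methoxybenzyl, and in this assay compound 2 gives 0.6 10^-6 cm/s. Compound 3 `CCCC[C@H](NC(=O)[C@H](CCCCN)NC(=O)[C@H](CCCNC(=N)N)NC(=O)c1ccc(/C=C2\SC(=S)N(c3ccc(OC)cc3)C2=O)cc1)C(N)=O` carries a 4-methoxyphenyl, and in this assay compound 3 gives 0.59 10^-6 cm/s, at the low end of the three numbers, though the difference from compound 2 is within the scatter: a 1.0-fold lower number from compound 2 to compound 3 (0.01 log units; within the scatter). The gap to compound 1 is beyond the scatter: a 2.7-fold lower number from compound 1 to compound 3 (0.44 log units; beyond the scatter).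

Compound 4 `CCCC[C@H](NC(=O)[C@H](CCCCN)NC(=O)[C@H](CCCNC(=N)N)NC(=O)c1ccc(/C=C2\SC(=S)N(C3CCCCC3)C2=O)cc1)C(N)=O` is the unmeasured member: cyclohexyl in place of 4-methoxyphenyl on an amide-type nitrogen in a ring. Because the step that gave a 2.7-fold lower number from compound 1 to compound 3 (0.44 log units; beyond the scatter) replaced a chain of carbon only with the very 4-methoxyphenyl that now leaves, it bears most on this change; the step of a 2.7-fold lower number from compound 1 to compound 2 (0.43 log units; beyond the scatter) was of similar size. Returning to a group of carbon only is therefore expected to raise the number, roughly a 2.0-fold higher number from compound 3 to compound 4 (0.31 log units; beyond the scatter), though a cyclohexyl is not a butyl, so the range is kept wide. Compound 4 is expected to give about 1.2 10^-6 cm/s in this assay, between 0.5 10^-6 cm/s and 2.6 10^-6 cm/s.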

Compound 4, apparent permeability: 1.82 10^-6 cm/s
Beside the measured number, compound 4's estimate is 1.5-fold (0.18 log units) below it, and the stated range covers the measured number.
By their numbers in this assay, from the lowest: compounds 3 and 2 (each within the scatter of the next); then compounds 1 and 4 (each within the scatter of the next).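

Exchanging the aromatic ring for a saturated ring of the same size on this nitrogen changes the result in this assay: the step is (a 3.1-fold higher number from compound 3 to compound 4 (0.49 log units; beyond the scatter)), and replacing the 4-methoxybenzyl gives a similar step (a 3.0-fold higher number from compound 2 to compound 4 (0.48 log units; beyond the scatter)). A ring at this position therefore does not always go with a low number, since the cyclohexyl of compound 4 and the open-chain butyl of compound 1 match (a 1.1-fold higher number from compound 1 to compound 4 (0.05 log units; within the scatter)); among these four compounds, the two low numbers belong to the two groups that carry a 4-methoxyphenyl unit, and no compound goes against this. Nothing available here explains the difference.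

This change removes the aromatic ring and the methoxy oxygen together, so the two cannot be told apart from these compounds. From the compounds shown here alone, a plain phenyl, which keeps the aromatic ring without the oxygen, or a 4-methoxycyclohexyl, which keeps the oxygen on a saturated ring, remains open.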